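The compounds below may be only part of what the source reports. "The series", "measured", "known", "first", "only" and "open" are said of these compounds alone.

Values in a functional assay on HEK293 cells for agonist activity at Bile acid receptor (Homo sapiens), read by a luciferase reporter; on this read-out lower numbers stand for smaller maximal responses and higher numbers for larger maximal responses:

compound 1 `CC(C)c1onc(-c2c(Cl)cccc2Cl)c1COc1ccc(NC(=O)c2ccc(C(=O)O)cc2)c(C(F)(F)F)n1`: 48%
compound 2 `CC(C)c1onc(-c2c(Cl)cccc2Cl)c1COc1ccc(N(C)Cc2cccc(C(=O)O)c2)c(C(F)(F)F)n1`: 58%
compound 3 `CC(C)c1onc(-c2c(Cl)cccc2Cl)c1COc1ccc(N(C)Cc2ccc(OCCO)cc2)c(C(F)(F)F)n1`: 59%

Compound 2 stands second highest of the three. Nearest is compound 3, a number 1 percentage points higher from compound 2 to compound 3 (within the scatter); furthest is compound 1, a number 10 percentage points higher from compound 1 to compound 2 (within the scatter). Both steps lie within the scatter, so the three numbers are effectively one level.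

Compound 4 `CC(C)c1onc(-c2c(Cl)cccc2Cl)c1COc1ccc(N(C)Cc2cccc(C(=O)NCCOP(=O)(O)O)c2)c(C(F)(F)F)n1` changes compound 2 on a carbonyl carbon: a group of 8 heavy atoms (2 carbon, 1 nitrogen, 4 oxygen, 1 phosphorus; no ring) in place of one oxygen atom, on a carbonyl carbon.

Neither measured step touches this position. The step from compound 1 to compound 2 reworked the whole linker, and that from compound 2 to compound 3 replaced the ring bearing the acid; each stayed within the scatter. On that basis no change beyond the scatter is expected for compound 4, with a number 1 percentage points lower from compound 2 to compound 4 (within the scatter). Compound 4 is estimated at 57%, range 44% to 70%.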

Compound 4, largest response reached (reported as efficacy), in percent of the reference or control that the assay uses: 61%
For compound 4 the middle estimate is 4 percentage points below the measured one; the range from low to high includes it.
By their numbers in this assay, from the lowest: compounds 1, 2, 3 and 4 (each within the scatter of the next, the first and the last beyond it).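

In this assay, the carbonyl carbon on the aromatic carbon takes a group of 8 heavy atoms, with phosphorus and no ring, in place of the hydroxy, and the result is a number 3 percentage points higher from compound 2 to compound 4 (within the scatter). The maximal response at this position therefore survives loss of the carboxylic acid and a much larger substituent. No data bearing on a cause are available. On these data alone, whether a methyl amide or a methyl ester on this carbonyl carbon reads the same remains open, as does whether a longer chain does.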